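The source may report more compounds than this note shows. Statements on the series, on what has been measured and on what is new or still open speak of the compounds shown alone.

Compound 1, `CS(=O)(=O)CCCn1c(Cn2c(=O)n(C3CC3)c3ccncc32)cc2cc(Cl)ccc21`: in an ADME assay on HeLa cells (Homo sapiens) for cytotoxicity, read by ATP content, with a stated time of 3 days (on this read-out higher numbers stand for lower toxicity in this test and lower numbers for higher toxicity in this test), compound 1 gives > 50000 nM, which is a limit of the assay and not a number.
Compound 2, `CC(C)CCn1c(Cn2c(=O)n(C3CC3)c3ccncc32)cc2ccccc21`: in this assay compound 2 gives > 100000 nM, again a limit rather than a number.
Compound 3, `CS(=O)(=O)CCCn1c(Cn2c(=O)n(C3CC3)c3ccncc32)cc2cc(C(F)(F)F)ccc21`: in this assay compound 3 gives > 50000 nM, also a limit.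

Compound 3 therefore stands at a limit, as do the two other measured compounds; none of the three shows a readable toxicity. Within the data shown here, the one measured step that changes a single place, a step that the two limits leave unreadable from compound 1 to compound 3, cannot be sized because both of its ends are limits (the limit of > 50000 nM in this assay, at which 2 of the 3 values shown sit), and compound 2 sits at a different limit (the limit of > 100000 nM in this assay, at which 1 of the 3 values shown sits).

Compound 4, `CS(=O)(=O)CCCn1c(Cn2c(=O)n(C3CC3)c3ccncc32)cc2ccccc21`, differs from compound 3 by hydrogen in place of trifluoromethyl on an aromatic carbon. Among the measured compounds shown here, no measured step bears directly on this change, since the step from compound 1 to compound 3 is unreadable and no step leads to compound 2. Nothing among the three measured compounds gives a reason to expect toxicity to appear, so in this assay the expected step that the limit leaves unreadable from compound 3 to compound 4 is none beyond the scatter, and most likely the assay will again report only a limit.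

Compound 4 is thus estimated at 100000 nM, with an expected range from 50000 nM to 300000 nM.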

Compound 4, half-maximal cytotoxic concentration: > 100000 nM
Compound 4: a limit, no number (the forecaster's own chance of this, stated with the estimate: 90%); the middle value sits exactly at the limit.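

The steps from compound 1, compound 2 and compound 3 to compound 4 cannot be read, because all four compounds give limits and no numbers, with compound 2 and compound 4 sharing one: the limit of > 100000 nM in this assay, at which 2 of the 4 values shown sit.

Compound 1 and compound 3 share the other: the limit of > 50000 nM in this assay, at which 2 of the 4 values shown sit.

The compounds shown leave open whether chloro, trifluoromethyl or hydrogen on the aromatic carbon changes toxicity in this assay at all.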